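The source may report more compounds than this note shows. Statements on the series, on what has been measured and on what is new or still open speak of the compounds shown alone.

Series notes. Compound 3 `CN(Cc1cn(C2CCCCC2O)nn1)CC1CCCCC1` and compound 1 `CN(Cc1cn(C2CCCCC2OC(=O)c2ccccc2)nn1)CC1CCCCC1` share one core; the pair differs by benzoyl in place of hydrogen on an oxygen on a saturated carbon. In an assay on nucleic acid for inhibition of Nucleic Acid, read by fluorescence, tested at 100 uM (on this read-out lower numbers stand for less inhibition and higher numbers for more inhibition at the one concentration tested (going by the name of the read-out)), compound 3 gives 47%, and compound 1 gives 32%; the step is a number 15 percentage points lower from compound 3 to compound 1 (beyond the scatter). Compound 2 `CCOC(=O)C1CCCN(Cc2cn(C3CCCCC3O)nn2)C1` carries a different core; the difference between the two cores is not broken down here. In this assay compound 2 gives 16%, the lowest of the three numbers, beyond the scatter from both compound 1 and compound 3. Compound 4 `CCOC(=O)C1CCCN(Cc2cn(C3CCCCC3OC(=O)c3ccccc3)nn2)C1` is not yet measured; it differs from compound 2 by benzoyl in place of hydrogen on an oxygen on a saturated carbon, the same change as that from compound 3 to compound 1, at the same place. Among the measured compounds shown here, the expected step is a number 11 percentage points lower from compound 2 to compound 4 (beyond the scatter), resting on the single precedent a number 15 percentage points lower from compound 3 to compound 1 (beyond the scatter); with one precedent only and a low starting number, the room downward is small. Compound 4 is estimated at 5%, between -6% and 18%.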

Compound 4, a percentage reported as inhibition, at one concentration (the size of the read-out at that concentration, not a potency): 11%
Beside the measured number, compound 4's estimate is 6 percentage points below it; the range from low to high includes it.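

In this assay the change from hydrogen to benzoyl gives a number 5 percentage points lower from compound 2 to compound 4 (within the scatter) on the core of compound 2. Set beside the earlier step, the size of the change does not differ between the two cores: the same change on two cores in this assay, a number 15 percentage points lower (beyond the scatter) from compound 3 to compound 1 and a number 5 percentage points lower (within the scatter) from compound 2 to compound 4, 10 percentage points apart, within the scatter of two such steps. The numbers fall on both cores and are compatible with one shared step, yet only the step on the core of compound 1 lies beyond the scatter, so a real fall on the core of compound 2 is not shown, and two cores cannot establish a rule for the series.

Only hydroxy and benzoyloxy appear on that oxygen-bearing position, leaving an acetyl ester, a methyl ether or an amine there open. Going by these compounds, whether the step holds with a carboxylic acid in place of the ethyl ester of compound 2 also stays open.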